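The compounds below may be only part of what the source reports. "The series", "measured", "known", "first", "only" and "open" are said of these compounds alone.

Measured in a functional assay on A549 cells (Homo sapiens) for inhibition, read by CCK-8 assay, with a stated time of 72 h, tested at 10 uM; on this read-out lower numbers stand for less inhibition of growth and higher numbers for more inhibition of growth at the one concentration tested:
- compound 1 `CN(C)C(=O)c1cc2cnc(Nc3ccc(NC(=O)C4(C(=O)Nc5cccc(F)c5)CC4)cc3)nc2n1C1CCCC1`: 91.8%
- compound 2 `CN(C)C(=O)c1cc2cnc(Nc3ccc(NC(=O)C4(C(=O)Nc5cccc(C(F)(F)F)c5)CC4)cc3)nc2n1C1CCCC1`: 89.2%
- compound 3 `COc1cccc(NC(=O)C2(C(=O)Nc3ccc(Nc4ncc5cc(C(=O)N(C)C)n(C6CCCC6)c5n4)cc3)CC2)c1`: 96%

Compound 3 stands within the scatter of both other compounds, as the steps show: a number 4.2 percentage points higher from compound 1 to compound 3 (within the scatter) and a number 6.8 percentage points higher from compound 2 to compound 3 (within the scatter). Compound 4 `CN(C)C(=O)c1cc2cnc(Nc3ccc(NC(=O)C4(C(=O)Nc5cccc(Br)c5)CC4)cc3)nc2n1C1CCCC1` has bromo in place of the methoxy of compound 3, on an aromatic carbon of a six-membered aromatic ring of carbon only, meta to a large group: bromo in place of methoxy on an aromatic carbon.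

Going by the values given here, three measured steps bear on this change, since each exchanges one group for another at this same place. Besides the two above, there is a number 2.6 percentage points lower from compound 1 to compound 2 (within the scatter). Among the compounds with values here, all three are small, and none leaves the scatter, but no measured compound carries bromo. In this assay, therefore, no step beyond the scatter is expected, and no direction can be firmly assigned. The expected change is a number 5 percentage points lower from compound 3 to compound 4 (within the scatter). For compound 4 the estimated value is 91%, with an expected range from 82% to 99%.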

Compound 4, percent growth inhibition at one concentration: 92.2%
Beside the measured number, compound 4's estimate is 1.2 percentage points below it; measured number inside the range.
By their numbers in this assay, from the lowest: compounds 2, 1, 4 and 3 (each within the scatter of the next).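

In this assay bromo at this place, on the six-membered aromatic ring and meta to a large group, gives a number 3.8 percentage points lower from compound 3 to compound 4 (within the scatter) and also a number 3 percentage points higher from compound 2 to compound 4 (within the scatter) and finally a number 0.4 percentage points higher from compound 1 to compound 4 (within the scatter). The position now carries four groups, fluoro, trifluoromethyl, methoxy and bromo, and no step among the listed compounds leaves the scatter, so bromo adds a halogen heavier than fluoro without establishing any order among the four. No measurement at hand offers an explanation for this result.

These values come from a single concentration, so the compounds shown leave open whether the four groups would separate in a full concentration series. Also open, from the compounds shown here alone, is whether an amine or a carboxylic acid at this place would stay within the same scatter.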